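Chloro for acetamido on the benzyl ring of the core

The source may hold more compounds than are shown below. What is called first, only, known or untested is meant among the compounds shown, and "the series" means these compounds.

Among the measured compounds shown here, compound 1 `CNc1nc(NCc2ccc(NC(C)=O)cc2)cc(-c2ccccn2)n1` gives 2 nM in a functional assay on HEK293 cells for agonist activity at G-protein coupled receptor 39 (Mus musculus), read by inositol phosphate accumulation (a lower number here means that less compound is needed, a higher number that more compound is needed for the effect), the lowest of the two numbers measured so far. Compound 2 `CNc1nc(NCC2CCCCC2)cc(-c2ccccn2)n1` gives 10 nM in this assay; the gap to compound 1 lies beyond the scatter. Compound 3 `CNc1nc(NCc2ccc(Cl)cc2)cc(-c2ccccn2)n1` awaits measurement. Its difference from compound 1: chloro in place of acetamido on an aromatic carbon. For the measured compounds named here, no measured pair shows a single change at this place, so the expectation rests on the spread between compound 1 and compound 2. A small loss, a 2.5-fold higher number from compound 1 to compound 3 (0.40 log units; beyond the scatter), is expected, near the edge of the scatter. Compound 3 is estimated at 5 nM, within 1.5 nM to 20 nM.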

Compound 3, half-maximal effective concentration: 3 nM
Beside the measured number, compound 3's estimate is 1.7-fold (0.22 log units) above it; measured number inside the range.
By their numbers in this assay, from the lowest: compounds 1 and 3 (each within the scatter of the next); then compound 2.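

In this assay, chloro and acetamido on this aromatic carbon cannot be told apart, with a 1.5-fold higher number from compound 1 to compound 3 (0.18 log units; within the scatter), so the acetamido group with its hydrogen-bond donor and acceptor is not needed to hold a number at this level. The ring itself does count, since 4-chlorophenyl in place of cyclohexyl gives a 3.3-fold lower number from compound 2 to compound 3 (0.52 log units; beyond the scatter), a modest gain. The data on hand offer no explanation for either step. Open, as far as these compounds go, is how an amine or a carboxylic acid on this aromatic carbon would read. Also open, from the compounds shown here alone, is whether an unsubstituted phenyl would keep this gain over cyclohexyl.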